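This account rests on a few compounds, and the source may have more. Where it says the series, first, only, none or still open, it means among the compounds named here.

In a functional assay on MCF7 cells (Homo sapiens) for antiproliferative activity, read by sulforhodamine B assay, with a stated time of 48 h (on this read-out lower numbers stand for stronger inhibition and higher numbers for weaker inhibition), three compounds on one shared core have been tested. Compound 1 (`COc1ccccc1OS(=O)(=O)c1ccc(N2CCN(C)C2=O)cc1`) gives 26000 nM and compound 3 (`CCCN1CCN(c2ccc(S(=O)(=O)Oc3ccccc3OC)cc2)C1=O`) gives 13000 nM and these two values lie within the scatter of each other. Compound 2 (`CCN1CCN(c2ccc(S(=O)(=O)Oc3ccccc3OC)cc2)C1=O`) shows > 100000 nM as a limit of the assay and not a number. Going by the values given here, compound 3 therefore stands level with compound 1, the only other compound with a true number.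

Compound 4 (`CCCN1CCN(c2ccc(S(=O)(=O)Oc3cccc(OC)c3)cc2)C1=O`) has the same atoms as compound 3, joined differently. It carries 3-methoxyphenyl in place of 2-methoxyphenyl on an oxygen whose other neighbour is the sulfonyl sulfur. The measured steps all lie on the saturated chain at the amide-type nitrogen in a ring, and none of them touches this group. Those steps are an at least 3.8-fold higher number from compound 1 to compound 2 (0.58 log units; beyond the scatter) and an at least 7.6-fold lower number from compound 2 to compound 3 (0.88 log units; beyond the scatter) beyond the scatter, and a 2.0-fold lower number from compound 1 to compound 3 (0.30 log units; within the scatter) within it. They give no direction for the present change, so this assay is expected to show no step beyond the scatter, although the size of an at least 7.6-fold lower number from compound 2 to compound 3 (0.88 log units; beyond the scatter) keeps the expected range wide. For compound 4 the estimate is 15000 nM with an expected range from 4000 nM to 60000 nM overall. The expected move is a 1.2-fold higher number from compound 3 to compound 4 (0.06 log units; within the scatter) and would lie within the scatter.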

Compound 4, half-maximal inhibitory concentration: 6300 nM
For compound 4 the middle estimate is 2.4-fold (0.38 log units) above the measured one, and the stated range covers the measured number.
By their numbers in this assay, from the lowest: compound 4; then compounds 3 and 1 (each within the scatter of the next). At a limit, above all of these: compound 2.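

Going by these compounds alone, the earlier steps all lay on the saturated chain at the amide-type nitrogen in a ring, so compound 4 is the first to show that the group on an oxygen whose other neighbour is the sulfonyl sulfur also matters in this assay. Putting 3-methoxyphenyl in place of 2-methoxyphenyl gives a 2.1-fold lower number from compound 3 to compound 4 (0.31 log units; beyond the scatter), a modest step that lies only just beyond the scatter, and it separates two arrangements of the same atoms rather than two different groups. Nothing among the data shown accounts for this step.

As far as these compounds go, the change is seen only once, with a single chain on the amide-type nitrogen, so it remains open whether it would hold with the shorter chains of compound 1 and compound 2. From the compounds shown here alone, how 4-methoxyphenyl, plain phenyl, or a ring carrying an amine or a carboxylic acid in place of the methoxy group would stand on that oxygen also remains open, as does whether a longer chain on the nitrogen would add to this step in this assay.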